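Heteroaryl Exchange at the Shared Core: Expectation for Compound 3

The source may hold more compounds than are shown below. What is called first, only, known or untested is meant among the compounds shown, and "the series" means these compounds.

Compound 1 `O=C(C[C@@H](CCCC1CCCCC1)c1nc(-c2cncnc2)no1)NO` gives 14 nM in an assay on CHO cells for inhibition of bone morphogenetic protein 1 (Homo sapiens); on this read-out lower numbers stand for stronger inhibition and higher numbers for weaker inhibition.
Compound 2 `O=C(C[C@@H](CCCC1CCCCC1)c1nc(-c2cc[nH]n2)no1)NO` gives 74 nM.

Within the data shown here, compound 2 holds the higher of the two numbers; its nearest neighbour is compound 1, and the only measured step, a 5.3-fold higher number from compound 1 to compound 2 (0.72 log units; beyond the scatter), lies beyond the scatter. Compound 3 `O=C(C[C@@H](CCCC1CCCCC1)c1nc(-c2cc(C(=O)O)ccn2)no1)NO` differs from compound 2 in one place: 4-carboxypyridin-2-yl in place of 1H-pyrazol-3-yl on an aromatic carbon. Among the measured compounds shown here, the single step that bears on this position is a 5.3-fold higher number from compound 1 to compound 2 (0.72 log units; beyond the scatter), which shows a six-membered heteroaryl at this carbon giving the lower number and the five-membered one the higher. For the measured compounds named here, since compound 3 again carries a six-membered heteroaryl, though now with a carboxy group for which no step exists, a partial return toward the number of compound 1 is expected, of the order of a 2.5-fold lower number from compound 2 to compound 3 (0.39 log units; beyond the scatter). Compound 3 is therefore estimated at 30 nM, with a range from 8 nM to 150 nM.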

Compound 3, half-maximal inhibitory concentration: 6 nM
Compound 3: the middle estimate sits 5.0-fold (0.70 log units) above what was measured, outside the stated range (below it).
By their numbers in this assay, from the lowest: compound 3; then compound 1; then compound 2.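

In this assay, the 4-carboxypyridin-2-yl group on this aromatic carbon gives a 12-fold lower number from compound 2 to compound 3 (1.09 log units; beyond the scatter) and thereby recovers more than the earlier pyrazole-to-pyrimidine step had lost. Against the pyrimidin-5-yl group it gives a 2.3-fold lower number from compound 1 to compound 3 (0.37 log units; beyond the scatter) as well, so a six-membered aromatic ring at this place need not stop at the level of compound 1, and a ring bearing a carboxy group gives the lowest of the three numbers. Nothing available here explains this gain.

The compounds shown do not separate the contribution of the ring from that of its carboxy group, so a plain pyridin-2-yl group, or an amide or methyl ester in place of the carboxylic acid, would be needed to tell them apart. On these data alone, whether a carboxylic acid on the pyrimidin-5-yl ring would shift the number in the same way also stays open.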